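Halogen swap on the cinnamoyl ring of compound 2

This account rests on a few compounds, and the source may have more. Where it says the series, first, only, none or still open, it means among the compounds named here.

Measured compounds:
compound 1 `COc1ccc(/C=C/C(=O)c2c(C)[n+]([O-])c3ccccc3[n+]2[O-])cc1OC` — 25000 nM
compound 2 `Cc1c(C(=O)/C=C/c2ccc(Cl)cc2)[n+]([O-])c2ccccc2[n+]1[O-]` — 13000 nM

The two compounds were tested in a functional assay on HSC-2 cells (Homo sapiens) for cytotoxicity, with a stated time of 48 h; a higher number here means that more compound is tolerated, a lower number that less compound is tolerated. Compound 1 gives 25000 nM, and compound 2 gives 13000 nM. Compound 2 has the lowest of the two numbers in this assay, but its nearest neighbour is compound 1, whose number lies within the scatter of repeated measurements, so the two values cannot be told apart.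

Compound 3 `Cc1c(C(=O)/C=C/c2ccc(F)cc2)[n+]([O-])c2ccccc2[n+]1[O-]` differs from compound 2 in one place: fluoro in place of chloro on an aromatic carbon. Within the data shown here, no step between measured compounds of this kind exists here, so the size of the change must be guessed. Halogen exchanges on this kind of ring are usually modest, and the step from compound 2 to compound 3 in this assay is expected to stay within the scatter, as a 1.4-fold higher number from compound 2 to compound 3 (0.14 log units; within the scatter). Compound 3 is therefore estimated at 18000 nM, in the range 6000 nM to 50000 nM.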

Compound 3, half-maximal cytotoxic concentration: 6200 nM
Compound 3: middle estimate off by 2.9-fold (0.46 log units), on the high side; low and high end bracket the measured number.
By their numbers in this assay, from the lowest: compound 3; then compounds 2 and 1 (each within the scatter of the next).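

In this assay, the change from 4-chlorophenyl to 4-fluorophenyl gives a 2.1-fold lower number from compound 2 to compound 3 (0.32 log units; beyond the scatter). Among these compounds, this is the first step here between compounds that differ in one place, and it shows that the number responds to the identity of a single halogen on an aromatic carbon para to a large group, with a modest step that lies beyond the scatter. No measurement on hand accounts for this difference between fluoro and chloro.

With only these two halogens compared at this position, one step cannot establish a trend across substituents. As far as these compounds go, how a bromo group, an amine or a carboxylic acid in the same place would compare with compound 3 remains open, as does whether the same halogen exchange would give a similar step in other compounds.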